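The source may hold more compounds than are shown below. What is called first, only, known or untested is meant among the compounds shown, and "the series" means these compounds.

Compound 1, `c1cc(-c2ccn[nH]2)c2c(c1)C(c1ncc[nH]1)CC2`, was examined in a functional assay on CHO cells for agonist activity at Alpha-1A adrenergic receptor (Homo sapiens), read by FLIPR and calcium flux (a higher number here means a larger maximal response, a lower number a smaller maximal response), where compound 1 gives 83%. Compound 2, `CS(=O)(=O)Nc1c(Cl)ccc2c1CCCC2c1ncc[nH]1`, was examined in the same way, and in this assay compound 2 gives 61%. Of the two numbers recorded so far, that of compound 1 is the highest, and the nearest, that of compound 2, lies lower by a gap that is beyond the usual scatter of this kind of measurement.

Compound 3, `c1cncc(-c2cccc3c2CCC3c2ncc[nH]2)c1`, has not yet been measured in this assay. It differs from compound 1 in one place: pyridin-3-yl in place of 1H-pyrazol-5-yl on an aromatic carbon. Going by the values given here, no pair of measured compounds differing in only one place is available, so the size of this step cannot be read from the data. The group that leaves carries one hydrogen-bond donor, the group that enters carries none, and a modest drop in maximal response is therefore expected rather than a rise, though a result within the scatter would not be surprising. The expected step is a number 13 percentage points lower from compound 1 to compound 3 (beyond the scatter). For compound 3 the estimate in this assay is 70%, with a range from 45% to 95%.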

Compound 3, largest response reached (Emax), in percent of the reference or control that the assay uses: 36%
Compound 3: middle estimate off by 34 percentage points, on the high side, and the stated range ends above it.
By their numbers in this assay, from the lowest: compound 3; then compound 2; then compound 1.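

Going by these compounds alone, the pair of compound 1 and compound 3 gives the first single-place step in this assay, and it is large: putting pyridin-3-yl in place of 1H-pyrazol-5-yl on this aromatic carbon gives a lower maximal response (a number 47 percentage points lower from compound 1 to compound 3 (beyond the scatter)). It shows that, on the core of compound 1, the maximal response depends strongly on which aromatic ring sits at this place, and that one aromatic nitrogen-containing ring cannot simply stand in for another here. The change alters ring size, the number of hetero atoms and the hydrogen-bond donor count all at once, and nothing measured separates these differences or explains the drop.

The two compounds leave open which of these differences matters, and a phenyl ring, 1-methylpyrazol-5-yl or 1H-imidazol-4-yl at this place would begin to pull them apart. They also leave open whether pyridin-4-yl or pyridin-2-yl would behave as pyridin-3-yl does, and whether a small group such as methoxy or an amine could hold the response at this carbon without a second aromatic ring.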